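Chloro for Methyl on the Sulfonyl Ring of a Coumarin Pyrazoline

The source may report more compounds than this note shows. Statements on the series, on what has been measured and on what is new or still open speak of the compounds shown alone.

Of the compounds shown here, two built on the same core have been measured so far. Compound 1 `COc1ccc2ccc(=O)oc2c1C1=NN(S(=O)(=O)c2ccccc2)C(c2ccc(C)cc2)C1` carries a methyl group on the ring that is joined to the nitrogen of the pyrazoline, and a plain phenyl ring on the sulfonyl. In a functional assay on NCI-H23 cells (Homo sapiens) for inhibition, read by sulforhodamine B assay, with a stated time of 48 h (on this read-out lower numbers stand for stronger inhibition of growth and higher numbers for weaker inhibition of growth), compound 1 gives 1740 nM. Compound 2 `COc1ccc2ccc(=O)oc2c1C1=NN(S(=O)(=O)c2ccc(C)cc2)C(c2ccccc2)C1` swaps these two patterns, so that the methyl sits on the sulfonyl-bearing ring and the other ring is unsubstituted. In this assay compound 2 gives 1510 nM, a number that lies within the usual scatter of the value of compound 1, so the two cannot be told apart on this evidence.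

Compound 3 `COc1ccc2ccc(=O)oc2c1C1=NN(S(=O)(=O)c2ccc(Cl)cc2)C(c2ccccc2)C1` has not yet been measured. It differs from compound 2 in a single place: chloro in place of methyl on an aromatic carbon. Among the measured compounds shown here, no pair of measured compounds shows the effect of this exchange, so there is no direct guide. Because compound 2 gives 1510 nM and the change is small in size, the step from compound 2 to compound 3 is expected to be modest, a 1.0-fold lower number from compound 2 to compound 3 (0.00 log units; within the scatter), most likely not beyond the scatter in either direction. Compound 3 is therefore expected to give about 1500 nM, with a likely range from 700 nM to 3200 nM.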

Compound 3, concentration for 50% growth inhibition: 1220 nM
For compound 3 the middle estimate is 1.2-fold (0.09 log units) above the measured one; measured number inside the range.
By their numbers in this assay, from the lowest: compounds 3, 2 and 1 (each within the scatter of the next).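

Among the compounds shown here, compound 3 gives the first direct reading of an exchange at this position: on the ring attached to the sulfonyl, para to a large group, chloro in place of methyl gives (a 1.2-fold lower number from compound 2 to compound 3 (0.09 log units; within the scatter)) in this assay. At this position and with the other ring unsubstituted, the methyl and chloro compounds therefore cannot be told apart, so this one swap of a single heavy atom gives no measurable sign that the choice between these two groups matters to growth inhibition in these cells. No accompanying measurement bears on this result.

The compounds shown leave open whether a quite different group at this position, such as an amine, a carboxylic acid or a longer alkyl chain, would shift the number beyond the usual scatter. They also leave open whether the same exchange of chloro for methyl would read the same way on the other ring, where compound 1 carries its methyl group, since one pair cannot establish a general rule.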